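Aryl swap on the saturated ring carbon of the shared core

The compounds below may be only part of what the source reports. "The series", "measured", "known", "first", "only" and "open" are said of these compounds alone.

Two members of the series have been measured so far. Compound 1 `COc1cc(/C=C/C(=O)C2=C(/C=C/c3ccc(O)c(OC)c3)NC(=O)NC2c2cccc([N+](=O)[O-])c2)ccc1O` gives 19.9% in a functional assay, with a stated time of 20 min, tested at 10 uM; on this read-out lower numbers stand for a weaker effect and higher numbers for a stronger effect at the one concentration tested. Compound 2 `COc1cc(/C=C/C(=O)C2=C(/C=C/c3ccc(O)c(OC)c3)NC(=S)NC2c2ccc(C)cc2)ccc1O` gives 19.9% in this assay, level with compound 1 at the digits reported, which is within the scatter of this read-out. Within the data shown here, no step between measured compounds is recorded, so the two values show only that changing the aryl group on the saturated ring carbon together with the urea-to-thiourea exchange left the read-out unchanged.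

Compound 3 `COc1cc(/C=C/C(=O)C2=C(/C=C/c3ccc(O)c(OC)c3)NC(=S)NC2c2c(Cl)cccc2Cl)ccc1O` keeps the thiourea of compound 2 and differs from it in one place: 2,6-dichlorophenyl in place of 4-methylphenyl on a saturated ring carbon.

Given that the pair of compound 1 and compound 2 shows no change in this assay across a different aryl swap at the same position, no step beyond the scatter is expected here either, in either direction. The step from compound 2 to compound 3 is estimated as a number 1.1 percentage points higher from compound 2 to compound 3 (within the scatter) in this assay. Compound 3 is therefore expected to give about 21% in this assay, with a likely range from 8% to 36%.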

Compound 3, a percentage reported as activity, at one concentration (the size of the read-out at that concentration, not a potency): 20.2%
For compound 3 the middle estimate is 0.8 percentage points above the measured one, and the stated range covers the measured number.
By their numbers in this assay, from the lowest: compounds 1, 2 and 3 (each within the scatter of the next).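

Among these compounds, with the thiourea held in common, 2,6-dichlorophenyl in place of 4-methylphenyl on a saturated ring carbon gives a number 0.3 percentage points higher from compound 2 to compound 3 (within the scatter) in this assay, and this is the first comparison in which only the aryl group at this position differs. Compound 1 and compound 2 differ in both the aryl group and the urea-to-thiourea exchange, whereas this pair ties the result to the aryl swap alone: an aryl group with two chlorine atoms and one with a single methyl group stay within the scatter of each other at this position. No measurement available here offers an explanation for this result.

The compounds shown all carry a six-membered aromatic ring of carbon only at this position, so it remains open whether a group of another kind, such as a cyclohexyl ring, or a phenyl ring bearing an amine or a carboxylic acid, would separate from them in this assay. The urea-to-thiourea exchange also remains unresolved, since no pair shown differs in that place alone.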